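The source may report more compounds than this note shows. Statements on the series, on what has been measured and on what is new or still open speak of the compounds shown alone.

Of the compounds shown here, three of one series have been tested in a functional assay on HL-60 cells (Homo sapiens) for inhibition, read by MTT assay, with a stated time of 72 h; on this read-out lower numbers stand for stronger inhibition and higher numbers for weaker inhibition. Compound 1 `COc1cc(OC)cc(N2CCN(C(=O)c3onc(C)c3-c3ccccc3)CC2)c1` gives 152 nM. Compound 2 `Cc1nc(-c2ccccc2)c(C(=O)N2CCN(c3c(C)cccc3C)CC2)o1` gives 146 nM, which is the second highest of the three numbers; compound 1 stands nearest to it, within the usual scatter, so nothing can be said about an order between compound 2 and compound 1. Compound 3 `COc1cccc(N2CCN(C(=O)c3oc(C)nc3-c3ccccc3F)CC2)c1` gives 56.1 nM, a lower number that lies beyond the scatter from compound 2. Compound 3 also differs from compound 2 in more than one place, so its lower number cannot be tied to any single change.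

The step from compound 2 to the untested compound 4 `Cc1nc(-c2ccccc2)c(C(=O)N2CCN(c3ccccc3)CC2)o1` is a single change: phenyl in place of 2,6-dimethylphenyl on an amine nitrogen in a ring. Among the measured compounds shown here, no measured pair in this set shows this change, and no measured pair differs in just one place. Since compound 1 and compound 2 carry different groups on the same ring nitrogen and still give numbers within the scatter of each other, the group at this place does not appear to move this assay strongly in the two cases seen. Compound 4 is therefore expected to give 190 nM, within 80 nM to 450 nM, with an expected step of a 1.3-fold higher number from compound 2 to compound 4 (0.11 log units; within the scatter), likely no more than the scatter.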

Compound 4, half-maximal inhibitory concentration: 39.1 nM
The estimate for compound 4 lay 4.9-fold (0.69 log units) above the measured number; the measured number lies below the stated range.
By their numbers in this assay, from the lowest: compounds 4 and 3 (each within the scatter of the next); then compounds 2 and 1 (each within the scatter of the next).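

On the shared core, the group on the amine nitrogen in the ring does move the read-out: in this assay, phenyl in place of 2,6-dimethylphenyl gives a 3.7-fold lower number from compound 2 to compound 4 (0.57 log units; beyond the scatter) and lies beyond the scatter. Among the compounds shown here, this is the first single-place change in the set, and it shows that this position is not as silent as the closeness of the two earlier numbers suggested, since those compounds also differ elsewhere and so could not isolate the group on this nitrogen. The step comes with the smaller group, phenyl in place of 2,6-dimethylphenyl, yet the information at hand offers no evidence on why the number falls, and the reason for this step remains unknown.

The compounds shown leave open whether a phenyl carrying just one methyl group would stand with compound 2 or with compound 4, and whether a pyridine ring or a benzyl group on the same nitrogen would keep the lower number. They also leave open whether the same change would give a step of similar size on the core of compound 1 or with the fluorine-bearing phenyl of compound 3.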